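Working notes: imide replacement from compound 1 to compound 3

The source may hold more compounds than are shown below. What is called first, only, known or untested is meant among the compounds shown, and "the series" means these compounds.

Measured so far:
Compound 1 `CC1(C)CC(=O)N(c2ccccc2C(=O)OCC2CCCN(CCCc3ccccc3)C2)C1=O` — in an in vitro functional assay on HEK ts201 cells for antagonist activity at Neuronal acetylcholine receptor; alpha3/beta4 (Homo sapiens), read by fluorescence and calcium flux (a lower number here means a stronger inhibitor, a higher number a weaker inhibitor), compound 1 gives 5010 nM.
Compound 2 `CN1CCCC(COC(=O)c2ccccc2-c2ccccc2)C1` — in this assay compound 2 gives 4790 nM.

Compound 1 has the highest of the two numbers, but compound 2 sits within the scatter of it, so no order between them is claimed. Compound 3 `O=C(OCC1CCCN(CCCc2ccccc2)C1)c1ccccc1N1C(=O)c2ccccc2C1=O` differs from compound 1 by a group of 11 heavy atoms (8 carbon, 1 nitrogen, 2 oxygen; one five-membered non-aromatic ring with 1 hetero atom, one six-membered aromatic ring of carbon only) in place of a group of 9 heavy atoms (6 carbon, 1 nitrogen, 2 oxygen; one five-membered non-aromatic ring with 1 hetero atom), on an aromatic carbon. Among the measured compounds shown here, no measured step of this kind exists. The change is expected to move the number little, a step of a 1.0-fold lower number from compound 1 to compound 3 (0.00 log units; within the scatter), not beyond the scatter. Compound 3 is therefore estimated at 5000 nM, with a range of 1600 nM to 16000 nM.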

Compound 3, half-maximal inhibitory concentration: 5890 nM
Compound 3: middle estimate off by 1.2-fold (0.07 log units), on the low side; low and high end bracket the measured number.
By their numbers in this assay, from the lowest: compounds 2, 1 and 3 (each within the scatter of the next).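

Replacing the 3,3-dimethyl-2,5-dioxopyrrolidin-1-yl group on this aromatic carbon with the larger group, which adds a six-membered aromatic ring, gives a 1.2-fold higher number from compound 1 to compound 3 (0.07 log units; within the scatter) in this assay. Among the compounds shown here, this is the first step read at this position, and the added ring leaves the number unchanged within the scatter. No supporting data bear on the reason for this result.

Open, going by these compounds, is whether an amine or a carboxylic acid on this aromatic carbon would give a step beyond the scatter. For the compounds shown here, the series so far also leaves open whether any group here can give a clearly stronger inhibitor.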